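A Nitro Group Takes the Place of Fluoro

The compounds below may be only part of what the source reports. "The series", "measured", "known", "first", "only" and "open" are said of these compounds alone.

In a functional assay on MDA-MB-231 cells (Homo sapiens) for antiproliferative activity, read by MTT assay, with a stated time of 48 h (on this read-out lower numbers stand for stronger inhibition and higher numbers for weaker inhibition), compound 3 `COC(=O)/C(=C/c1ccccc1)CN1C(=O)[C@@H](OC)[C@H]1c1cccc(F)c1` gives 34400 nM and holds the higher of the two numbers available. Compound 1 `COC(=O)/C(=C/c1ccccc1)CN1C(=O)[C@@H](OC)[C@H]1c1ccc(Cl)cc1` gives 15600 nM on the same read-out, while for compound 2 `COC(=O)/C(=C/c1ccccc1)CN1C(=O)[C@@H](OC)[C@H]1c1cccc(Cl)c1` there is no result reported on that read-out. Compound 4 `COC(=O)/C(=C/c1ccccc1)CN1C(=O)[C@@H](OC)[C@H]1c1cccc([N+](=O)[O-])c1` differs from compound 3 in one group nitro in place of fluoro on an aromatic carbon with nitro in place of fluoro on an aromatic carbon. Among the measured compounds shown here, the only measured step that bears on this is a 2.2-fold higher number from compound 1 to compound 3 (0.34 log units; beyond the scatter) and it is modest, but it concerns a different exchange, so it is only a rough guide to size. In this assay a small move of no firm direction is expected, likely within the scatter. The expected change is a 1.3-fold lower number from compound 3 to compound 4 (0.11 log units; within the scatter) on this estimate. Compound 4 is estimated at 27000 nM with 11000 nM to 65000 nM as the expected range.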

Compound 4, half-maximal inhibitory concentration: 14400 nM
Compound 4: middle estimate off by 1.9-fold (0.27 log units), on the high side, and the stated range covers the measured number.
By their numbers in this assay, from the lowest: compounds 4 and 1 (each within the scatter of the next); then compound 3.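

Nitro in place of fluoro on the aromatic carbon gives a 2.4-fold lower number from compound 3 to compound 4 (0.38 log units; beyond the scatter) in this assay, which shows that the group at this position can shift the number beyond the scatter. 3-Nitrophenyl in place of 4-chlorophenyl gives a 1.1-fold lower number from compound 1 to compound 4 (0.03 log units; within the scatter) on the same read-out, so these two aryl groups cannot be told apart here. No measurement offered here accounts for either step. Still open, going by these compounds, is how an amine or a carboxylic acid at this aromatic carbon would read, and whether a methoxy group would fall with nitro or with fluoro.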